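Swapping a Sulfonamide for a Methoxy on the Amide Ring

The compounds below may be only part of what the source reports. "The series", "measured", "known", "first", "only" and "open" are said of these compounds alone.

Of the compounds shown here, three sharing one core have been tested in a functional assay (Homo sapiens) for inhibition, using a membrane potential dye, in the presence of a further agent that is not named here; a lower number here means a stronger inhibitor, a higher number a weaker inhibitor. Compound 1, `COc1ccc(NC(=O)c2cc(N)ccc2Oc2ccc(OC)cc2)cc1`, shows "no significant activity" (no number reported) there. Compound 2, `CCN(C(=O)c1cc([N+](=O)[O-])ccc1Oc1ccc(OC)cc1)c1ccc(Cl)cc1`, gives 8300 nM in this assay. Compound 3, `COc1ccc(Oc2ccc([N+](=O)[O-])cc2C(=O)Nc2ccc(S(N)(=O)=O)cc2)cc1`, gives 1800 nM in this assay, the lowest number of the two compounds that have a number; the gap to compound 2 lies beyond the scatter of repeated measurements, so compound 3 is the stronger inhibitor of those two.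

Compound 4, `COc1ccc(NC(=O)c2cc([N+](=O)[O-])ccc2Oc2ccc(OC)cc2)cc1`, is the compound still to be measured. It differs from compound 3 in one place: methoxy in place of sulfamoyl on an aromatic carbon. Within the data shown here, no pair of measured compounds differs only in this way, so no measured step shows the effect directly. Compound 1 gives "no significant activity" (no number reported) although it carries the same methoxy group as compound 4, with an amino group where compound 4 carries a nitro group, which points toward weaker inhibition once the sulfamoyl is gone. Compound 4 is therefore expected to come out weaker, a 3.9-fold higher number from compound 3 to compound 4 (0.59 log units; beyond the scatter), by more than the usual scatter. Compound 4 is estimated at 7000 nM, within a range from 2000 nM to 30000 nM, with a fair chance that only a limit is reported.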

Compound 4, half-maximal inhibitory concentration: 3400 nM
Beside the measured number, compound 4's estimate is 2.1-fold (0.31 log units) above it, and the stated range covers the measured number.
By their numbers in this assay, from the lowest: compounds 3 and 4 (each within the scatter of the next); then compound 2.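

In this assay the swap of sulfamoyl for methoxy on this aromatic carbon, para to a large group and with the nitro group kept, gives a 1.9-fold higher number from compound 3 to compound 4 (0.28 log units; within the scatter) and so shows that the sulfamoyl is not needed for the inhibition seen in compound 3, even though methoxy brings no hydrogen-bond donor. The other end of the amide makes a measurable difference: (4-methoxyphenyl)amino in place of (4-chlorophenyl)(ethyl)amino on the carbonyl carbon gives a 2.4-fold lower number from compound 2 to compound 4 (0.39 log units; beyond the scatter) as a modest step, but this swap changes the ring substituent and the ethyl group together, so it cannot say which of the two counts. No measurement is available that would account for either step.

From the compounds shown here alone, whether this aromatic carbon would also tolerate a carboxylic acid, an amine or a plain hydrogen remains open. Also open, going by these compounds, is what a methyl or ethyl group on the amide nitrogen would do with the 4-methoxyphenyl group kept, and what a group such as a nitrile would do in place of the nitro group.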